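The compounds below may be only part of what the source reports. "The series", "measured", "known", "first", "only" and "open" are said of these compounds alone.

Compound 1 `O=C(/C=C/c1ccccc1)Nc1ccc2c(c1)OCCO2`: > 4000 nM
Compound 2 `CC(C)c1ccc(/C=C/C(=O)Nc2ccc3c(c2)OCCO3)cc1`: 82 nM

In a functional assay on CHO cells for inhibition of transient receptor potential cation channel subfamily V member 1 (Homo sapiens) (on this read-out lower numbers stand for stronger inhibition and higher numbers for weaker inhibition), compound 2 gives 82 nM, the only number shown. Compound 1 sits at the limit of > 4000 nM in this assay, at which 1 of the 2 values shown sits, a limit rather than a number. Within the data shown here, the single measured step, an at least 48-fold lower number from compound 1 to compound 2 (1.68 log units; beyond the scatter), is large and shows that isopropyl in place of hydrogen gave a much lower number. Compound 3 `O=C(/C=C/c1ccc(-c2ccccc2)cc1)Nc1ccc2c(c1)OCCO2` differs from compound 2 by phenyl in place of isopropyl on an aromatic carbon. Among the measured compounds shown here, that step replaces one group with another at the same place, which no measured step covers, so only a modest step is expected: a 1.3-fold higher number from compound 2 to compound 3 (0.13 log units; within the scatter). Compound 3 is therefore estimated at 110 nM, between 25 nM and 500 nM.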

Compound 3, half-maximal inhibitory concentration: > 4000 nM
Compound 3: only a limit was reported; the forecaster's own chance of this, stated with the estimate: 10%; middle value at least 36-fold (1.56 log units) from the limit.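

This position does not accept just any carbon group: phenyl in place of isopropyl gives an at least 48-fold higher number from compound 2 to compound 3 (1.68 log units; beyond the scatter), so the gain seen with isopropyl does not carry over to every larger group. Compound 3, like compound 1, gives only a limit and not a number, so the step separating them cannot be read: the limit of > 4000 nM in this assay, at which 2 of the 3 values shown sit.

The compounds shown leave open how narrow the range of accepted groups at this place is. An ethyl, tert-butyl or cyclopropyl group there would show whether the low number stays close to that of isopropyl.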